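A Methyl Added to the Benzoxazole of Compound 3

The compounds below may be only part of what the source reports. "The series", "measured", "known", "first", "only" and "open" are said of these compounds alone.

Compound 1 `O=C(O)c1csc(SCCN2C(=O)CC[C@@H]2/C=C/[C@@H](O)Cc2cccc(-c3ccccc3)c2)n1` gives 0.94 nM in an assay on CHO cells for displacement of a labelled ligand from prostaglandin E2 receptor EP4 subtype (Mus musculus), read by scintillation counting, with a stated time of 60 min; on this read-out higher numbers stand for weaker inhibition and lower numbers for stronger inhibition. Compound 2 `O=C(O)c1csc(SCCN2C(=O)CC[C@@H]2/C=C/[C@@H](O)Cc2cccc(-c3ccc(Cl)cc3)c2)n1` gives 0.81 nM, and a 1.2-fold lower number from compound 1 to compound 2 (0.06 log units; within the scatter). Compound 3 `Cc1ccc2oc(-c3cccc(C[C@H](O)/C=C/[C@H]4CCC(=O)N4CCSc4nc(C(=O)O)cs4)c3)nc2c1` gives 0.21 nM, the lowest of the three numbers; a 4.5-fold lower number from compound 1 to compound 3 (0.65 log units; beyond the scatter) and a 3.9-fold lower number from compound 2 to compound 3 (0.59 log units; beyond the scatter). Compound 4 `Cc1cc(C)c2oc(-c3cccc(C[C@H](O)/C=C/[C@H]4CCC(=O)N4CCSc4nc(C(=O)O)cs4)c3)nc2c1` differs from compound 3 in that (methyl in place of hydrogen on an aromatic carbon). Among the measured compounds shown here, the one earlier step of similar kind, a single small group placed on a distal aromatic ring, is a 1.2-fold lower number from compound 1 to compound 2 (0.06 log units; within the scatter), which stayed within the scatter, so no step beyond the scatter is expected here. Compound 4 is therefore estimated to give 0.22 nM, with a range from 0.09 nM to 0.55 nM. The expected step is a 1.0-fold higher number from compound 3 to compound 4 (0.02 log units; within the scatter).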

Compound 4, inhibition constant: 0.15 nM
Beside the measured number, compound 4's estimate is 1.5-fold (0.17 log units) above it; measured number inside the range.
By their numbers in this assay, from the lowest: compounds 4 and 3 (each within the scatter of the next); then compounds 2 and 1 (each within the scatter of the next).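

The added methyl, which turns 5-methyl-1,3-benzoxazol-2-yl into 5,7-dimethyl-1,3-benzoxazol-2-yl, leaves the result in this assay within the scatter (a 1.4-fold lower number from compound 3 to compound 4 (0.15 log units; within the scatter)). The dimethyl compound also stays clear of the two biphenyl-type compounds (a 5.4-fold lower number from compound 2 to compound 4 (0.73 log units; beyond the scatter); a 6.3-fold lower number from compound 1 to compound 4 (0.80 log units; beyond the scatter)), and both steps lie beyond the scatter. Nothing available bears on why this position responds as it does. From the compounds shown here alone, whether a methoxy group or an amine on the same aromatic carbon would behave like methyl remains open. So does the result for the plain 1,3-benzoxazol-2-yl group.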